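The source may report more compounds than this note shows. Statements on the series, on what has been measured and on what is new or still open speak of the compounds shown alone.

Series notes, metabolic stability. Among the compounds with values here, compound 3 `CCCCCCCCc1ccc(OC(C)C(=O)Cn2nnc(-c3ccc(C(=O)O)cc3)n2)cc1` is the one member with a number in an ADME assay on S9 fraction from liver (Rattus norvegicus) for metabolic stability, read by LC-MS, using NADPH, with a stated time of 30 min (on this read-out lower numbers stand for a less stable compound and higher numbers for a more stable compound), where compound 3 gives 55%. Compound 1 `CC(Oc1ccc(Oc2ccc(Cl)cc2)cc1)C(=O)Cn1nnc(-c2ccc(Cl)cc2)n1` gives in this assay < 5%, a limit. Compound 2 `COC(=O)c1ccc(-c2nnn(CC(=O)C(C)Oc3ccc(Oc4ccc(Cl)cc4)cc3)n2)cc1` gives in this assay < 5%, likewise a limit. The step that the two limits leave unreadable from compound 1 to compound 2 is therefore unreadable; see (the limit of < 5% in this assay, at which 2 of the 3 values shown sit).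

Compound 4 `CC(Oc1ccc(Oc2ccc(Cl)cc2)cc1)C(=O)Cn1nnc(-c2ccc(C(=O)O)cc2)n1` differs from compound 3 by 4-chlorophenoxy in place of octyl on an aromatic carbon. Within the data shown here, no measured step covers this change, so the only guide is that compound 1 also carries 4-chlorophenoxy and sits at a limit in this assay. Compound 4 is accordingly expected to fall at 15%, with a range of 3% to 40%. The expected step is a number 40 percentage points lower from compound 3 to compound 4 (beyond the scatter), downward.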

Compound 4, percent of the compound remaining: 32%
Estimate against measurement, compound 4: 17 percentage points below, within the range that was stated.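

In this assay, 4-chlorophenoxy in place of octyl gives a number 23 percentage points lower from compound 3 to compound 4 (beyond the scatter), so with carboxy on the other aromatic ring both groups leave a readable value. With 4-chlorophenoxy held, carboxy in place of chloro gives a number at least 27 percentage points higher from compound 1 to compound 4 (beyond the scatter), and hydrogen in place of the methyl of methoxycarbonyl gives a number at least 27 percentage points higher from compound 2 to compound 4 (beyond the scatter). Both of these steps start from a limit, so only their minimum size can be read: the limit of < 5% in this assay, at which 2 of the 4 values shown sit.

As far as these compounds go, what a shorter alkyl chain or an amine gives in place of octyl stays open. So does the result of an amide in place of carboxy.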